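The compounds below may be only part of what the source reports. "The series", "measured", "known", "first", "only" and "open" are said of these compounds alone.

Compounds measured so far in an assay on brain for binding affinity to adenosine receptor A1 (Rattus norvegicus), read by radioligand binding; a lower number here means a stronger inhibitor, a higher number a weaker inhibitor:
Compound 1, `CCCn1c(=O)c2nc(-c3ccc(OCC(=O)NCCN=C(S)Nc4ccc(C)cc4)cc3)[nH]c2n(CCC)c1=O`: 16 nM
Compound 2, `CCCn1c(=O)c2nc(-c3ccc(OCC(=O)NCCN=C(S)Nc4ccc(F)cc4)cc3)[nH]c2n(CCC)c1=O`: 15.5 nM

Among the measured compounds shown here, compound 2 gives the lowest of the two numbers in this assay, but its only neighbour is compound 1, and the step of a 1.0-fold lower number from compound 1 to compound 2 (0.01 log units; within the scatter) lies within the scatter, so the two compounds cannot be ordered against each other. That single step exchanges a substituent on the outer aromatic ring, and nothing else.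

Compound 3, `CCCn1c(=O)c2nc(-c3ccc(OCC(=O)NCCNC(=O)CBr)cc3)[nH]c2n(CCC)c1=O`, is not yet measured. From compound 2 it differs by a group of 5 heavy atoms (2 carbon, 1 nitrogen, 1 oxygen, 1 bromine; no ring) in place of a group of 11 heavy atoms (7 carbon, 2 nitrogen, 1 fluorine, 1 sulfur; one six-membered aromatic ring of carbon only), on a saturated chain carbon, two bonds along the chain from an amide-type nitrogen. For the measured compounds named here, no measured step bears directly on this exchange: the one step available, a 1.0-fold lower number from compound 1 to compound 2 (0.01 log units; within the scatter), shows only that a substituent change on the ring that now leaves made no difference beyond the scatter, and says nothing about removing that ring together with the part that carries it. The shared core of compound 2 and the linker up to the amide-type nitrogen are kept. Going by the values given here, with no step that speaks for a shift in either direction, compound 3 is expected to come out near compound 2, as a step of a 1.9-fold higher number from compound 2 to compound 3 (0.29 log units; within the scatter), with a wide range. The estimate for compound 3 in this assay is 30 nM, between 7 nM and 150 nM.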

Compound 3, inhibition constant: 17.6 nM
Estimate against measurement, compound 3: 1.7-fold (0.23 log units) above, within the range that was stated.
By their numbers in this assay, from the lowest: compounds 2, 1 and 3 (each within the scatter of the next).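

In this assay, putting ((bromomethyl)carbonyl)amino on a saturated chain carbon, two bonds along the chain from an amide-type nitrogen, in place of the group of 11 heavy atoms gives a 1.1-fold higher number from compound 2 to compound 3 (0.06 log units; within the scatter) and, from the methyl-bearing version of that group, a 1.1-fold higher number from compound 1 to compound 3 (0.04 log units; within the scatter) as the matching step. The earlier pair covered only a substituent exchange on the six-membered aromatic ring, whereas these steps show that the ring and the part carrying it can be replaced by a group of 5 heavy atoms with no ring, and all three compounds stay within the scatter of one another at this position. No supporting measurement bears on this result.

The compounds shown leave open whether the bromine matters at this position, which an acetyl group or a chloroacetyl group in the same place would test, and whether a free amine or a carboxylic acid in that place would also stay within the scatter. As far as these compounds go, a longer chain to the amide-type nitrogen, and any change to the shared core, also remain open.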